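Moving the Methyl Group: From Compound 2 to Compound 4

The source may hold more compounds than are shown below. What is called first, only, known or untested is meant among the compounds shown, and "the series" means these compounds.

Of the compounds shown here, three have been measured in an ADME assay on microsomes from liver (Mus musculus) for metabolic stability, read by LC-MS; a higher number here means faster removal of the compound, a lower number slower removal. Compound 2 `C[C@H]1CCCC[C@H]1NC(=O)c1cc2c(F)cc(F)cc2[nH]1` gives 660 mL.min-1.g-1, and compound 1 `Cc1cc(C)c2cc(C(=O)N[C@@H]3CCCC[C@@H]3C)[nH]c2c1` gives 433 mL.min-1.g-1. That gap lies within the usual scatter of repeated measurements, so these two count as alike. Compound 3 `C[C@H]1CC[C@H](NC(=O)c2cc3c(Cl)cc(Cl)cc3[nH]2)CC1` gives 3.4 mL.min-1.g-1, a much lower number that lies far beyond the scatter from compound 2.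

The unmeasured compound 4 `C[C@H]1CC[C@H](NC(=O)c2cc3c(F)cc(F)cc3[nH]2)CC1` has the same atoms as compound 2, joined differently: 4-methylcyclohexyl in place of 2-methylcyclohexyl on an amide-type nitrogen.

Among the measured compounds shown here, no two measured compounds differ in only one place, so the size of this step cannot be read directly from the data. For the measured compounds named here, the only clue is compound 3, which carries the same 4-methylcyclohexyl group and gives 3.4 mL.min-1.g-1 in this assay, yet it differs from compound 2 in more than one place. A single compound is thin evidence, so a downward step beyond the scatter is expected, but not one as large as the whole gap to compound 3. The estimated step of a 13-fold lower number from compound 2 to compound 4 (1.12 log units; beyond the scatter) would mean slower removal. The estimated value for compound 4 is 50 mL.min-1.g-1, with an expected range from 8 mL.min-1.g-1 to 300 mL.min-1.g-1.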

Compound 4, intrinsic clearance in microsomes in the Mus musculus assay: 149 mL.min-1.g-1
Compound 4: the middle estimate sits 3.0-fold (0.47 log units) below what was measured, and the stated range covers the measured number.
By their numbers in the Mus musculus assay, from the lowest: compound 3; then compound 4; then compounds 1 and 2 (each within the scatter of the next).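

In the Mus musculus assay, moving the methyl group on the ring while the rest of the molecule stays the same gives a 4.4-fold lower number from compound 2 to compound 4 (0.65 log units; beyond the scatter), which means slower removal. Among the compounds shown here, the group that leaves and the group that enters hold the same atoms, so this pair shows that the place of the methyl group alone, in a cyclohexyl on this amide-type nitrogen, can shift the number by more than the scatter, something the earlier compounds could not show because they differed in more than one place at once. In a physicochemical assay for solubility, measured as thermodynamic solubility, with a stated time of 24 h, at pH 6.8 (a higher number here means a more soluble compound, a lower number a less soluble compound), compound 2 gives < 4000 nM as a limit of the assay and not a number. In the physicochemical assay compound 4 gives < 4000 nM as a limit of the assay and not a number. In the physicochemical assay no step can be read for the same change, as compound 2 and compound 4 each stand at a limit of the assay rather than at a number: the limit of < 4000 nM in the physicochemical assay, at which 2 of the 2 values shown sit.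

The compounds shown leave open where a 3-methylcyclohexyl or a plain cyclohexyl on the same nitrogen would fall in the Mus musculus assay, and what a cyclohexyl carrying a hydroxyl group or an amine would do there. They also leave open whether the same move of the methyl group gives a step of similar size on the core of compound 1.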